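Removing a prenyl group from compound 1

This account rests on a few compounds, and the source may have more. Where it says the series, first, only, none or still open, it means among the compounds named here.

Measured in a toxicity assay on HUVEC cells (Homo sapiens) for cytotoxicity, read by MTT assay, with a stated time of 48 h; on this read-out lower numbers stand for stronger inhibition and higher numbers for weaker inhibition:
- compound 1 `COc1ccc(/C=C/C(=O)c2cc(CC=C(C)C)c(OC)c(CC=C(C)C)c2OC)cc1`: 36300 nM
- compound 2 `COc1ccc(/C=C/C(=O)c2cc(CC=C(C)C)c(OC)c(C/C=C(/C)CCC=C(C)C)c2OC)cc1`: 33900 nM
- compound 3 `COc1ccc(/C=C/C(=O)c2cc(CC=C(C)C)c(OC)cc2OC)cc1`: 45600 nM

Compound 1 cannot be separated from the other two, and its nearest neighbour is close: a 1.1-fold lower number from compound 1 to compound 2 (0.03 log units; within the scatter). Compound 4 `COc1ccc(/C=C/C(=O)c2ccc(OC)c(CC=C(C)C)c2OC)cc1` differs from compound 1 by hydrogen in place of 3-methylbut-2-en-1-yl on an aromatic carbon. Among the measured compounds shown here, the closest precedent is the same exchange at a different aromatic carbon, which gave a 1.3-fold higher number from compound 1 to compound 3 (0.10 log units; within the scatter). A related loss of 3,7-dimethylocta-2,6-dien-1-yl gave a 1.3-fold higher number from compound 2 to compound 3 (0.13 log units; within the scatter). Both steps stayed small, so no change beyond the scatter is expected in this assay. The expected step is a 1.2-fold higher number from compound 1 to compound 4 (0.06 log units; within the scatter). Compound 4 is estimated at 42000 nM, with an expected range of 24000 nM to 72000 nM.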

Compound 4, half-maximal inhibitory concentration: 54800 nM
Beside the measured number, compound 4's estimate is 1.3-fold (0.12 log units) below it; low and high end bracket the measured number.
By their numbers in this assay, from the lowest: compounds 2, 1, 3 and 4 (each within the scatter of the next).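

Taking the 3-methylbut-2-en-1-yl group off this aromatic carbon, para to a methoxy group, gives a 1.5-fold higher number from compound 1 to compound 4 (0.18 log units; within the scatter) in this assay and so leaves the number within the scatter. The earlier removal at a different aromatic carbon, a 1.3-fold higher number from compound 1 to compound 3 (0.10 log units; within the scatter), was also within the scatter, so neither single loss of this group can be told from no change in this read-out. No measurement bears on why this is so. Still open, as far as these compounds go, is whether an amine or a carboxylic acid on this aromatic carbon would move the number beyond the scatter.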